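A few compounds are considered here, and "the series" means these few. Any claim that something is new, unique, unknown or untested is made for them only; others in the source may bear on it.

Measured in a functional assay on BeWo cells (Homo sapiens) for inhibition, read by MTT assay, with a stated time of 72 h; on this read-out higher numbers stand for weaker inhibition and lower numbers for stronger inhibition:
- compound 1 `CC(=O)N1CCN(c2nnc3nncn3n2)CC1` gives 13100 nM in the series
- compound 2 `CN(C)c1nnc2nncn2n1` gives 610 nM in the series
- compound 3 `CCCCNc1nnc2nncn2n1` gives 8640 nM in the series

Compound 1, at 13100 nM, sits at the weak end of these numbers, and compound 3, at 8640 nM, lies within the scatter of it. Compound 2, at 610 nM, stands well apart from compound 1, beyond the scatter, on the side of stronger inhibition.

The next compound is compound 4 `CN1CCN(c2nnc3nncn3n2)CC1`, which has methyl in place of acetyl on an amine nitrogen in a ring and keeps the rest of compound 1 unchanged. Within the data shown here, no pair of measured compounds differs in one place only, so the size of this step has no direct precedent in this assay and any figure for it is loose.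

The two compounds without acetyl point in different directions. Compound 2 at 610 nM suggests that stronger inhibition is possible, while compound 3 at 8640 nM shows that losing acetyl does not guarantee it. A moderate move towards stronger inhibition is therefore expected, only modestly beyond the scatter.

The expected step of a 3.7-fold lower number from compound 1 to compound 4 (0.57 log units; beyond the scatter) is an estimate with wide uncertainty. For compound 4 the estimated value is 3500 nM, with an expected range of 700 nM to 14000 nM in this assay for now.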

Compound 4, half-maximal inhibitory concentration: 7990 nM
Compound 4: the middle estimate sits 2.3-fold (0.36 log units) below what was measured; the measured number falls inside the stated range.
By their numbers in this assay, from the lowest: compound 2; then compounds 4, 3 and 1 (each within the scatter of the next).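

In this assay, among these compounds, methyl in place of acetyl on an amine nitrogen in a ring gives the first one-place step, a 1.6-fold lower number from compound 1 to compound 4 (0.21 log units; within the scatter). On this read-out, the two groups cannot be told apart at this position, so a carbonyl on this ring nitrogen is not needed to keep the level of inhibition seen for compound 1, and the larger acetyl can give way to methyl without a change beyond the scatter. No measurement at hand bears on why the two groups read alike.

Still open, from the compounds shown here alone, is whether any other group on this ring nitrogen, such as a longer chain, a benzyl group or a sulfonamide, would move the number beyond the scatter, or whether this position tolerates a wide range of groups without a real shift. Going by these compounds, compound 2 and compound 3 each differ from compound 1 and compound 4 in more than one place; steps to them cannot be read, and what a one-place change elsewhere on the shared core would do remains unknown.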